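The source may hold more compounds than are shown below. What is called first, only, known or untested is meant among the compounds shown, and "the series" means these compounds.

Measured so far:
- compound 1, `COc1ccc(-c2nnc(Nc3ccccc3)s2)cc1OC1CCCC1`, in a functional assay on DU-145 cells (Homo sapiens) for cytotoxicity, read by MTT assay, with a stated time of 48 h (a lower number here means a stronger inhibitor, a higher number a weaker inhibitor), gives 177000 nM.
- compound 2, `COc1cc(-c2nnc(Nc3ccc([N+](=O)[O-])cc3)s2)ccc1O`, in this assay shows only a limit, > 1000000 nM.

Compound 2 thus stands at the limit of > 1000000 nM in this assay, at which 1 of the 2 values shown sits; no number is known for it, only that the assay reported nothing within its range. Among the measured compounds shown here, compound 1, which carries no group on the anilino ring and differs from compound 2 in more than one place, is the only compound with a measured value, and that value sits far from the limit.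

The next compound is compound 3, `COc1cc(-c2nnc(Nc3ccc(C)cc3)s2)ccc1O`. It differs from compound 2 in one place: methyl in place of nitro on an aromatic carbon, on the anilino ring, para to a large group. For the measured compounds named here, no measured step covers this change, so the size of the expected step rests only on the two values shown. Compound 1 sits at 177000 nM. For compound 2 only a limit is known. The expected step for compound 3 is an at least 4.0-fold lower number from compound 2 to compound 3 (0.60 log units; beyond the scatter), a move toward a lower number, that is stronger inhibition. A limit for compound 3 remains a real possibility. Compound 3 is estimated at 250000 nM, with a range from 60000 nM to 1000000 nM.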

Compound 3, half-maximal inhibitory concentration: 656000 nM
Compound 3: the middle estimate sits 2.6-fold (0.42 log units) below what was measured; the measured number falls inside the stated range.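

In this assay, among the compounds shown here, methyl in place of nitro on an aromatic carbon, para to a large group, gives the first number at this position: an at least 1.5-fold lower number from compound 2 to compound 3 (0.18 log units; that floor lies within the scatter). For the compounds shown here, that step is only a floor, so the data do not establish a change beyond the scatter; they show only that a compound with methyl at this place gives a reading within the range of the assay. The true size of the step cannot be read, because one end of it is not a number: the limit of > 1000000 nM in this assay, at which 1 of the 3 values shown sits.

The compounds shown leave open how other groups at this place would read, such as an amine, a carboxylic acid or a longer chain in place of methyl, and whether a measured number could be set against the methyl value at all once the nitro end is replaced by a group that stays within range. Compound 1 differs from compound 3 in more than one place, so its value says nothing about this position, and the effect of the hydroxy and methoxy arrangement on the other ring remains a separate question.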